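From 4-bromophenyl to 2,5-dimethylphenyl on the shared core

This account rests on a few compounds, and the source may have more. Where it says the series, first, only, none or still open, it means among the compounds named here.

Within the data shown here, in a functional assay (muscle tissue) with Cavia porcellus as the target (on this read-out lower numbers stand for an effect already at smaller amounts and higher numbers for an effect only at larger amounts of compound), compound 3 (`COC(=O)C1=C(C)N=C(C)/C(=C(\O)OC)C1c1ccc(Br)cc1`) gives 540 nM and so stands highest of the three numbers measured so far. On the same core, compound 1 (`COC(=O)C1=C(C)N=C(C)/C(=C(\O)OC)C1c1cccc(OC)c1`) gives 191 nM and compound 2 (`CCc1ccccc1C1C(C(=O)OC)=C(C)N=C(C)/C1=C(\O)OC`) gives 6.46 nM in this assay as well. Compound 4 (`COC(=O)C1=C(C)N=C(C)/C(=C(\O)OC)C1c1cc(C)ccc1C`) carries 2,5-dimethylphenyl in place of 4-bromophenyl on a saturated ring carbon.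

All three measured steps change this same place. The step of a 2.8-fold higher number from compound 1 to compound 3 (0.45 log units; beyond the scatter) is modest, while a 30-fold lower number from compound 1 to compound 2 (1.47 log units; beyond the scatter) and an 84-fold higher number from compound 2 to compound 3 (1.92 log units; beyond the scatter) are large, so the number moves widely with the group found here. Among the measured compounds shown here, no measured compound carries the entering group. Its closest measured relative is the 2-ethylphenyl of compound 2, which likewise bears only carbon on the phenyl and has its group numbered 2. A large step towards a lower number is therefore expected, though probably not one that spans the whole gap between compound 3 and compound 2. The expected change is a 15-fold lower number from compound 3 to compound 4 (1.19 log units; beyond the scatter) in this assay on this reasoning. Compound 4 is thus estimated at 35 nM (expected range 8 nM to 150 nM).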

Compound 4, half-maximal effective concentration: 100 nM
Beside the measured number, compound 4's estimate is 2.9-fold (0.46 log units) below it; measured number inside the range.
By their numbers in this assay, from the lowest: compound 2; then compounds 4 and 1 (each within the scatter of the next); then compound 3.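

In this assay the change to 2,5-dimethylphenyl gives a 5.4-fold lower number from compound 3 to compound 4 (0.73 log units; beyond the scatter) and so counts as modest, while a 15-fold higher number from compound 2 to compound 4 (1.19 log units; beyond the scatter) is a large step, which shows that a phenyl bearing only carbon groups does not by itself reach the number of compound 2 at this position. The step of a 1.9-fold lower number from compound 1 to compound 4 (0.28 log units; within the scatter) lies within the scatter, so the 2,5-dimethylphenyl and the 3-methoxyphenyl cannot be told apart here, and of the four groups only the 2-ethylphenyl and the 4-bromophenyl stand clearly apart from this pair. Nothing shown here gives any measurement that would explain these differences.

The compounds shown leave open whether the number of compound 2 belongs to the 2-ethylphenyl alone or would carry over to a longer chain such as propyl on the phenyl, and whether an amine or a nitro group there would fall nearer compound 2 or nearer compound 3. Every step shown changes this one place, and what a longer ester in place of the methoxycarbonyl group would do on the shared core stays unknown.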